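This account rests on a few compounds, and the source may have more. Where it says the series, first, only, none or still open, it means among the compounds named here.

Working notes, series measured in a functional assay on PC-3 cells (Homo sapiens) for cytotoxicity, read by colorimetric assay; a higher number here means a weaker inhibitor, a lower number a stronger inhibitor:

- compound 1 `O=C(/C=C/c1ccc(CN2C(=O)/C(=C3\Nc4ccccc4\C3=N/O)c3cccc(Cl)c32)cc1)NO`: 90 nM
- compound 2 `COc1ccc2c(c1)/C(=C1/Nc3ccccc3/C1=N\O)C(=O)N2Cc1ccc(/C=C/C(=O)NO)cc1`: 30 nM
- compound 3 `O=C(/C=C/c1ccc(CN2C(=O)/C(=C3\Nc4ccccc4\C3=N/O)c3cc(Br)ccc32)cc1)NO`: 90 nM

Compound 3 shares the highest of the three numbers with compound 1, and the two show no difference at the digits given. Compound 2 sits lower, at 30 nM.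

The next compound is compound 4 `O=C(/C=C/c1ccc(CN2C(=O)/C(=C3\Nc4ccccc4\C3=N/O)c3ccccc32)cc1)NO`, which has hydrogen in place of bromo on an aromatic carbon. It has not yet been measured in this assay.

For the measured compounds named here, no measured step removes a group and leaves hydrogen, so the evidence is indirect. Going by the values given here, the only measured step that bears on this change is a 3.0-fold higher number from compound 2 to compound 3 (0.48 log units; beyond the scatter), also bromo in place of methoxy on an aromatic carbon, and it is modest. Compound 1 carries chloro rather than bromo, on a different carbon, and gives 90 nM, the same number as compound 3. These few data give no sign of a large swing, and they do not fix a direction. A small move toward a lower number is expected, probably no larger than the scatter. The estimated change is a 1.5-fold lower number from compound 3 to compound 4 (0.18 log units; within the scatter). For compound 4 the expected value is 60 nM, with an estimated range of 25 nM to 150 nM.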

Compound 4, half-maximal inhibitory concentration: 50 nM
Compound 4: the middle estimate sits 1.2-fold (0.08 log units) above what was measured; the measured number falls inside the stated range.
By their numbers in this assay, from the lowest: compounds 2, 4, 1 and 3 (each within the scatter of the next, the first and the last beyond it).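

Hydrogen on this aromatic carbon gives the series its first reference without a substituent in this assay: a 1.8-fold lower number from compound 3 to compound 4 (0.26 log units; within the scatter), and likewise a 1.7-fold higher number from compound 2 to compound 4 (0.22 log units; within the scatter), so neither removing bromo nor removing methoxy gives a change that can be told from the scatter. The chloro comparison reads the same, a 1.8-fold lower number from compound 1 to compound 4 (0.26 log units; within the scatter), although chloro sits on a different carbon of the ring, so that step does not separate the identity of the group from its place. The only separation on this carbon is therefore the one between the two substituents, a 3.0-fold higher number from compound 2 to compound 3 (0.48 log units; beyond the scatter), with hydrogen within the scatter of both, and nothing available here explains these numbers.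

Still open, going by these compounds, is whether a group of another kind on this aromatic carbon, such as an amine, a carboxylic acid or a longer alkoxy chain, would move the number beyond the scatter from the hydrogen of compound 4. Also open is how bromo or methoxy would behave on the carbon that carries chloro in compound 1, since no pair shown holds one group on both carbons.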